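Cytotoxicity of Two Thioureas and an Iodophenyl Variant

This account rests on a few compounds, and the source may have more. Where it says the series, first, only, none or still open, it means among the compounds named here.

Compound 1 `Fc1ccccc1NC(=S)Nc1cccc(C(F)(F)F)c1`: 47000 nM
Compound 2 `Cc1ccc(NC(=S)Nc2cccc(C(F)(F)F)c2)cc1Cl`: 20000 nM

Both measured compounds share a thiourea core carrying a trifluoromethylphenyl group. In an ADME assay on MT4 cells (Homo sapiens) for cytotoxicity (a higher number here means that more compound is tolerated, a lower number that less compound is tolerated), compound 1 gives 47000 nM, the higher of the two numbers, so more of it is tolerated by the cells. Compound 2, in which a methyl- and chloro-substituted phenyl replaces the 2-fluorophenyl of compound 1, is tolerated less well: in this assay compound 2 gives 20000 nM, and the gap between the two lies beyond the usual scatter of repeated measurements.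

Compound 3 `FC(F)(F)c1cccc(NC(=S)Nc2ccc(I)cc2)c1` has not yet been measured. It differs from compound 1 in one place: 4-iodophenyl in place of 2-fluorophenyl on an amide-type nitrogen. For the measured compounds named here, no measured pair shows this exact change, so there is no direct precedent to lean on. With only compound 1 and compound 2 as guides, the step of a 1.6-fold lower number from compound 1 to compound 3 (0.19 log units; within the scatter) is expected to be small, leaning toward a somewhat lower number, and may well fall within the scatter. Compound 3 is therefore estimated at 30000 nM in this assay, with a plausible range from 10000 nM to 80000 nM.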

Compound 3, half-maximal cytotoxic concentration: 10000 nM
Estimate against measurement, compound 3: 3.0-fold (0.48 log units) above, within the range that was stated.
By their numbers in this assay, from the lowest: compounds 3 and 2 (each within the scatter of the next); then compound 1.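

Placing 4-iodophenyl in place of 2-fluorophenyl on the amide-type nitrogen is the first single-place change available, and in this assay it gives a 4.7-fold lower number from compound 1 to compound 3 (0.67 log units; beyond the scatter). The group at this position therefore matters to how much compound the cells tolerate, even though both groups count the same heavy atoms, have one six-membered aromatic ring of carbon only, and carry no hydrogen-bond donors or acceptors. No supporting data are available to explain this drop.

From the compounds shown here alone, how 2-iodophenyl or 4-fluorophenyl would behave here remains open, so the effect of swapping fluorine for iodine cannot yet be told apart from that of the substituent's place on the ring. Also open, going by these compounds, is how the cells would respond to a phenyl carrying an amine or a carboxylic acid at this position.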